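Aryl sulfonate ureas against HT-29 cells: a hydroxyphenyl replacement

A few compounds are considered here, and "the series" means these few. Any claim that something is new, unique, unknown or untested is made for them only; others in the source may bear on it.

Measured so far:
compound 1, `CCc1ccccc1OS(=O)(=O)c1ccc(NC(=O)NCCCCl)cc1`, 15000 nM in a functional assay on HT-29 cells (Homo sapiens) for cytotoxicity, read by sulforhodamine B assay, with a stated time of 48 h; on this read-out lower numbers stand for stronger inhibition and higher numbers for weaker inhibition
compound 2, `CCCc1ccccc1OS(=O)(=O)c1ccc(NC(=O)NCCCCl)cc1`, 13000 nM in this assay

Compound 2 stands at the lowest of the two numbers in this assay, with compound 1 nearest: the step of a 1.2-fold lower number from compound 1 to compound 2 (0.06 log units; within the scatter) is within the scatter, so the two compounds cannot be told apart on these data.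

Compound 3, `O=C(NCCCCl)Nc1ccc(S(=O)(=O)Oc2ccc(O)cc2)cc1`, has not yet been measured in this assay. It differs from compound 2 by 4-hydroxyphenyl in place of 2-propylphenyl on an oxygen whose other neighbour is the sulfonyl sulfur.

Among the measured compounds shown here, no measured step touches the ring on the sulfonate oxygen; the single step from compound 1 to compound 2 concerns only the chain on that ring and was within the scatter. There is therefore no measured basis for predicting a shift in either direction, and the expectation is anchored on compound 2 with a wide range. Compound 3 is accordingly estimated at 15000 nM, between 4000 nM and 60000 nM, which corresponds to an expected step of a 1.2-fold higher number from compound 2 to compound 3 (0.06 log units; within the scatter).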

Compound 3, half-maximal inhibitory concentration: 50000 nM
Estimate against measurement, compound 3: 3.3-fold (0.52 log units) below, and the stated range covers the measured number.
By their numbers in this assay, from the lowest: compounds 2 and 1 (each within the scatter of the next); then compound 3.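

Changing the ring on the oxygen whose other neighbour is the sulfonyl sulfur moves the number in this assay in a way that the chain step did not. Placing 4-hydroxyphenyl there in place of 2-propylphenyl gives a 3.8-fold higher number from compound 2 to compound 3 (0.59 log units; beyond the scatter), and placing it there in place of 2-ethylphenyl gives a 3.3-fold higher number from compound 1 to compound 3 (0.52 log units; beyond the scatter). Both steps are modest but beyond the scatter and point towards weaker inhibition, so this position is not indifferent to the group it carries, and compound 3 is the weakest of the three; nothing available here accounts for the change.

Each step removes an alkyl-bearing ring and brings in a hydroxyl-bearing one, so the compounds shown cannot separate the loss of the ethyl or propyl chain from the arrival of the hydroxyl group, or either of these from the change in where the substituent sits. On these data alone, it also remains open how an unsubstituted phenyl, a 4-methoxyphenyl or a 4-aminophenyl on that oxygen would compare with these three compounds.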